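The source may report more compounds than this note shows. Statements on the series, on what has been measured and on what is new or still open speak of the compounds shown alone.

Compound 3 `CC(=O)Nc1ccc(CNCC2(O)CCN(CCCc3c[nH]c4ccc(-n5cnnc5)cc34)CC2)cc1` carries the highest number of the three compounds measured in a functional assay on CHO cells for agonist activity at 5-hydroxytryptamine receptor 1D (Homo sapiens), read by GTPgammaS binding; on this read-out lower numbers stand for an effect already at smaller amounts and higher numbers for an effect only at larger amounts of compound: compound 3 gives 14 nM. Compound 1 `OC1(CNCc2ccccc2)CCN(CCCc2c[nH]c3ccc(-n4cnnc4)cc23)CC1` gives 2.2 nM, and compound 2 `CC(C)(C)OC(=O)NCC1(O)CCN(CCCc2c[nH]c3ccc(-n4cnnc4)cc23)CC1` gives 9.7 nM. The measured steps were a 6.4-fold higher number from compound 1 to compound 3 (0.80 log units; beyond the scatter), a 4.4-fold higher number from compound 1 to compound 2 (0.64 log units; beyond the scatter) and a 1.4-fold higher number from compound 2 to compound 3 (0.16 log units; within the scatter). Compound 4 `CN(CC1CCCCC1)CC1(O)CCN(CCCc2c[nH]c3ccc(-n4cnnc4)cc23)CC1` has not yet been measured; it differs from compound 3 by (cyclohexylmethyl)(methyl)amino in place of (4-acetamidobenzyl)amino on a saturated chain carbon bound to a saturated ring carbon. The step from compound 1 to compound 3, which added the acetamido group, bears most on this change, and it was only modest, as was the step from compound 1 to compound 2. A lower number is therefore expected for compound 4, the expected step being a 3.5-fold lower number from compound 3 to compound 4 (0.54 log units; beyond the scatter). Compound 4 is estimated at 4 nM, within a range from 1.5 nM to 12 nM.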

Compound 4, concentration for half-maximal effect: 1.4 nM
Estimate against measurement, compound 4: 2.9-fold (0.46 log units) above, outside the stated range (below it).
By their numbers in this assay, from the lowest: compounds 4 and 1 (each within the scatter of the next); then compounds 2 and 3 (each within the scatter of the next).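

With (cyclohexylmethyl)(methyl)amino on this saturated chain carbon, this assay shows a 10-fold lower number from compound 3 to compound 4 (1.00 log units; beyond the scatter) and also a 6.9-fold lower number from compound 2 to compound 4 (0.84 log units; beyond the scatter) in this series. The entering group has no aromatic ring and no hydrogen-bond donors, yet a 1.6-fold lower number from compound 1 to compound 4 (0.20 log units; within the scatter) stays within the scatter, so an aromatic ring in this group is not needed for a low number here. The compounds shown leave open whether the added methyl or the cyclohexyl ring counts more, which benzyl(methyl)amino could help separate. Nothing available explains these differences.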